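Swapping an Ester for a Thiazole in an Amide Series

This account rests on a few compounds, and the source may have more. Where it says the series, first, only, none or still open, it means among the compounds named here.

Compound 1 `CC(C)(C)OC(=O)c1cccc(NC(=O)C2CCCN(C(=O)c3cc(C(F)(F)F)cc(C(F)(F)F)c3)C2)c1` was examined in an ADME assay on PC-3 cells (Homo sapiens) for cytotoxicity, read by WST assay, tested at 100 uM (a higher number here means more inhibition at the concentration tested (going by the name of the read-out), a lower number less inhibition), where compound 1 gives 0%. Compound 2 `N#Cc1cccc(C(=O)N2CCCC(C(=O)Nc3ccc(Cl)cc3)C2)c1` belongs to the same set, and in this assay compound 2 gives 0%. No step between these two has been worked out, so only their two values can be set side by side: compound 1 stands level with compound 2 at the digits shown, and the two values lie within the scatter of one another.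

Compound 3 `Cc1nc(-c2cccc(NC(=O)C3CCCN(C(=O)c4cc(C(F)(F)F)cc(C(F)(F)F)c4)C3)c2)cs1` has not yet been tested in this assay. It differs from compound 1 in one place: 2-methyl-1,3-thiazol-4-yl in place of tert-butoxycarbonyl on an aromatic carbon

Both measured compounds show no inhibition, and the change touches only the group on the aromatic carbon. In this assay the expected step is a number 5 percentage points higher from compound 1 to compound 3 (within the scatter), that is, nothing beyond the scatter or at most a slight rise. Compound 3 is estimated to give 5% in this assay, within a range from 0% to 25%.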

Compound 3, a percentage reported as inhibition, at one concentration (the size of the read-out at that concentration, not a potency): 1%
Beside the measured number, compound 3's estimate is 4 percentage points above it; the measured number falls inside the stated range.
By their numbers in this assay, from the lowest: compounds 1, 2 and 3 (each within the scatter of the next).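

In this assay, putting 2-methyl-1,3-thiazol-4-yl in place of tert-butoxycarbonyl on this aromatic carbon gives a number 1 percentage points higher from compound 1 to compound 3 (within the scatter) and so leaves the reading where it was. For the compounds shown here, this is the first step read at this position, and it shows that an ester and a five-membered aromatic ring can be exchanged here without a change beyond the scatter. Since both ends of the step lie close to no inhibition, it says little about how the position would behave in a compound that does inhibit, and nothing measured here offers an explanation for the result.

The compounds shown leave open whether an amine or a carboxylic acid on the same aromatic carbon would move the reading in this assay beyond the scatter. They also leave open whether the same exchange would read alike with another group in place of the two trifluoromethyl groups.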